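Moving the Methyl and Dropping the Fluorine on the Urea Aryl

The source may report more compounds than this note shows. Statements on the series, on what has been measured and on what is new or still open speak of the compounds shown alone.

Compound 1 `Cc1ccccc1NC(=O)Nc1cc(C(C)(C)C)nn1-c1ccccc1`: 7.1 degrees C
Compound 2 `Cc1cc(C)cc(NC(=O)Nc2cc(C(C)(C)C)nn2-c2ccccc2)c1`: 2.4 degrees C
Compound 3 `Cc1ccc(F)cc1NC(=O)Nc1cc(C(C)(C)C)nn1-c1ccccc1`: 6 degrees C

In an assay on isolated protein for inhibition of STE20-like serine/threonine-protein kinase (Homo sapiens), read by thermal shift assay, tested at 10 uM (a higher number here means that the compound stabilises the target more against heat, a lower number that the compound stabilises the target less), compound 3 stands second highest of the three, below compound 1 and well above compound 2. Compound 4 `Cc1ccc(NC(=O)Nc2cc(C(C)(C)C)nn2-c2ccccc2)cc1` carries the change (4-methylphenyl in place of 5-fluoro-2-methylphenyl on an amide-type nitrogen). Two earlier steps bear on it. Changing the substitution pattern of the same aryl group gave a number 4.7 degrees C lower from compound 1 to compound 2 (beyond the scatter), a large loss, while a number 3.6 degrees C higher from compound 2 to compound 3 (beyond the scatter) recovered part of it. Since compound 4 again rearranges the pattern and gives up the fluorine, a loss is expected, though smaller than that large step. Compound 4 is expected to give 3.5 degrees C, with a range from 1.5 degrees C to 5.5 degrees C. The expected step is therefore a number 2.5 degrees C lower from compound 3 to compound 4 (beyond the scatter).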

Compound 4, shift of the target's melting temperature: 4.6 degrees C
The estimate for compound 4 lay 1.1 degrees C below the measured number; the measured number falls inside the stated range.
By their numbers in this assay, from the lowest: compound 2; then compound 4; then compound 3; then compound 1.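

In this assay, 4-methylphenyl on the amide-type nitrogen falls short of 2-methylphenyl, with a number 2.5 degrees C lower from compound 1 to compound 4 (beyond the scatter), and of 5-fluoro-2-methylphenyl, with a number 1.4 degrees C lower from compound 3 to compound 4 (beyond the scatter), yet exceeds 3,5-dimethylphenyl, with a number 2.2 degrees C higher from compound 2 to compound 4 (beyond the scatter). Across these four compounds, the two aryl groups with 2-methyl in their names give the two highest numbers, and no compound shown goes against this order. No measurement at hand explains the order. From the compounds shown here alone, whether a chloro or methoxy group in place of that methyl would keep the higher numbers remains open, as does the effect of an amine on this aryl group.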